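The source may hold more compounds than are shown below. What is called first, only, known or untested is meant among the compounds shown, and "the series" means these compounds.

Three compounds measured in an ADME assay on S9 fraction from liver (Rattus norvegicus) for metabolic stability, with a stated time of 1 h (a higher number here means that more of the compound is left, a lower number that less of the compound is left), form the starting point:

Compound 1 (`N#Cc1cnc(NCc2cnccc2C(F)(F)F)cc1N[C@H]1C[C@@H](O)C1`): 70%
Compound 2 (`N#Cc1cnc(NCc2ccccc2C(F)(F)F)cc1N[C@H]1CC[C@@H](O)CC1`): 31%
Compound 3 (`CO[C@H]1CC[C@@H](Nc2cc(NCc3cnccc3C(F)(F)F)ncc2C#N)CC1`): 1%

Compound 3 stands lowest of the three in this assay with 1% left. Both others lie beyond the scatter above it: compound 2 is nearer with 31% and compound 1 is further with 70% in the same read-out.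

The unmeasured compound 4 (`N#Cc1cnc(NCc2cnccc2C(F)(F)F)cc1NCCC1CCOCC1`) has the same atoms as compound 3, joined differently: 2-(oxan-4-yl)ethyl in place of 4-methoxycyclohexyl on a nitrogen on an aromatic ring.

For the measured compounds named here, only one measured step bears on this place, and it is large: a number 69 percentage points lower from compound 1 to compound 3 (beyond the scatter) with 4-methoxycyclohexyl in place of 3-hydroxycyclobutyl. Going by the values given here, it shows that a change here can reach far beyond the scatter, but the group entering compound 4 appears in no measured compound, so it fixes no size. Compound 2 differs from compound 3 in more than one place and gives no clean comparison. Compound 3 at 1% has almost no room to fall, so any step beyond the scatter should be upward. A moderate rise is expected, with an estimate of a number 14 percentage points higher from compound 3 to compound 4 (beyond the scatter) and wide uncertainty. Compound 4 is expected in this assay at an estimated 15% (range 1% to 45%).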

Compound 4, percent of the compound remaining: 0%
Beside the measured number, compound 4's estimate is 15 percentage points above it; the whole stated range lies above it.
By their numbers in this assay, from the lowest: compounds 4 and 3 (each within the scatter of the next); then compound 2; then compound 1.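

In this assay, 2-(oxan-4-yl)ethyl in place of 4-methoxycyclohexyl, the same atoms joined differently, gives a number 1 percentage points lower from compound 3 to compound 4 (within the scatter), so this read-out does not separate the two groups, with so little of either compound left. The new group also gives a number 70 percentage points lower from compound 1 to compound 4 (beyond the scatter), which shows that the large distance from the 3-hydroxycyclobutyl compound seen earlier is not particular to 4-methoxycyclohexyl: it holds for two groups of the same atoms, one with a ring of carbon only and one with a hetero atom in its ring. No measurement shown here accounts for these results.

The compounds shown leave open whether the hydroxy group or the small ring of compound 1 goes with its higher number, since compound 3 and compound 4 differ from it in both. A 3-methoxycyclobutyl group on the same nitrogen would begin to separate the two, and an oxan-4-yl group attached directly to that nitrogen would show whether the ethyl chain of compound 4 matters at all.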